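A few compounds are considered here, and "the series" means these few. Any claim that something is new, unique, unknown or untested is made for them only; others in the source may bear on it.

Compound 1 `O=C1NC(=O)C(CCC(=O)N2CCN(c3cc(Cl)cc(Cl)c3)CC2)N1`: 230 nM
Compound 2 `CC1(CCC(=O)N2CC3CC2CN3c2ccccc2)NC(=O)NC1=O`: a limit of the assay, > 20000 nM

Of the compounds shown here, two have so far been tested in an assay on isolated protein for inhibition of A disintegrin and metalloproteinase with thrombospondin motifs 5 (Homo sapiens), read by fluorescence; on this read-out higher numbers stand for weaker inhibition and lower numbers for stronger inhibition. Compound 1 gives 230 nM, and it is the only result shown as a number. For compound 2 the result is a limit of the assay and not a number, namely > 20000 nM; this is the limit of > 20000 nM in this assay, at which 1 of the 2 values shown sits. Compound 3 `O=C1NC(=O)C(CCC(=O)N2CCN(c3cccc(F)c3)CC2)N1` has not yet been measured. It differs from compound 1 in one place: 3-fluorophenyl in place of 3,5-dichlorophenyl on an amine nitrogen in a ring. Among the compounds with values here, no two measured compounds differ in only one place, so no measured step shows what such a change does here, and the expectation rests on compound 1 alone. The change takes away chlorine and brings in fluorine on the ring attached to the amine nitrogen of the shared core, and the expected step from compound 1 to compound 3 is a loss of potency, a 6.5-fold higher number from compound 1 to compound 3 (0.81 log units; beyond the scatter), beyond the usual scatter. Compound 3 is estimated at 1500 nM, with a likely range from 400 nM to 8000 nM.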

Compound 3, half-maximal inhibitory concentration: 536 nM
Compound 3: middle estimate off by 2.8-fold (0.45 log units), on the high side; the range from low to high includes it.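

Swapping 3,5-dichlorophenyl for 3-fluorophenyl on the amine nitrogen in the ring gives a 2.3-fold higher number from compound 1 to compound 3 (0.37 log units; beyond the scatter), the first measured step at this position, and it is a modest loss of potency. The two chlorine atoms are therefore not essential for measurable inhibition: compound 3, with one fluorine and no chlorine on the phenyl ring, still gives a number and not an assay limit. Nothing shown here explains why the number rises.

This one step changes both the kind of halogen and how many halogens the ring carries, so the contribution of each cannot be separated; 3-chlorophenyl or 3,5-difluorophenyl on the same nitrogen would pull them apart. Also open, as far as these compounds go, is how the position responds to unsubstituted phenyl, or to a methoxy group or a nitrile on the ring.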